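The source may report more compounds than this note shows. Statements on the series, on what has been measured and on what is new or still open speak of the compounds shown alone.

Measured compounds:
Compound 1, `O=C(CCl)Nc1ccc(C(=O)/C=C/c2ccc(Br)cc2)cc1`: in a functional assay on SMMC-7721 cells (Homo sapiens) for cytotoxicity, read by MTT assay, with a stated time of 72 h (a lower number here means a stronger inhibitor, a higher number a weaker inhibitor), compound 1 gives 13300 nM.
Compound 2, `O=C(CCl)Nc1ccc(C(=O)/C=C/c2ccc(F)cc2)cc1`: in this assay compound 2 gives 15100 nM.

Compound 2 holds the higher of the two numbers, but its nearest neighbour is compound 1, and the step from one to the other is a 1.1-fold higher number from compound 1 to compound 2 (0.06 log units; within the scatter), which lies within the scatter, so the two compounds cannot be told apart on these data.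

Compound 3, `O=C(CSC(=S)N[C@H]1CCOC1=O)Nc1ccc(C(=O)/C=C/c2ccc(F)cc2)cc1`, differs from compound 2 by a group of 10 heavy atoms (5 carbon, 1 nitrogen, 2 oxygen, 2 sulfur; one five-membered non-aromatic ring with 1 hetero atom) in place of one chlorine atom, on a saturated chain carbon bound to a carbonyl carbon. Within the data shown here, no measured step touches this part of the molecule: the only step available, a 1.1-fold higher number from compound 1 to compound 2 (0.06 log units; within the scatter), concerns the halogen on the aromatic ring of the shared core and was itself within the scatter. There is therefore no measured guide to the size or direction of the change from compound 2 to compound 3, and the expectation rests on the value of compound 2, 15100 nM, with a wide range around it. For compound 3 the step from compound 2 is expected to be a 1.7-fold lower number from compound 2 to compound 3 (0.22 log units; within the scatter). Compound 3 is therefore estimated at 9000 nM, with a likely range from 2000 nM to 40000 nM.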

Compound 3, half-maximal inhibitory concentration: > 128000 nM
Compound 3 was reported as a limit; the forecaster's own chance of this, stated with the estimate: 10%; middle value at least 14-fold (1.15 log units) away from the limit.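

The earlier pair changed only the halogen on an aromatic carbon, and that step lay within the scatter, so it said nothing about the chain that carries the chloro group. Here, the group of 10 heavy atoms in place of chlorine, on a saturated chain carbon bound to a carbonyl carbon, gives an at least 8.4-fold higher number from compound 2 to compound 3 (0.92 log units; beyond the scatter), the first step beyond the scatter in this assay and a first sign that this position is not indifferent to change. The result for compound 3 is a limit, so the step has a lower bound but no known full size: the limit of > 128000 nM in this assay, at which 1 of the 3 values shown sits.

The compounds shown cannot separate the loss of the chloro group from the arrival of this particular group, since a single replacement stands at this position. On these data alone, it remains open whether a small amine, a hydroxyl group or a simple methylthio group on that chain carbon would stay near compound 2, and whether the five-membered ring or the sulfur-bearing link carries the change.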